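Sulfonamide group variation on the shared core: compound 4

The compounds below may be only part of what the source reports. "The series", "measured", "known", "first", "only" and "open" are said of these compounds alone.

Measured so far:
compound 1 `O=S(=O)(NCCN1CCCCC1)c1ccc(-c2ccnc3[nH]ccc23)cc1` — 6600 nM
compound 2 `CC(C)(C)OC(=O)NCCNS(=O)(=O)c1ccc(-c2ccnc3[nH]ccc23)cc1` — no result reported
compound 3 `CN(CCO)S(=O)(=O)c1ccc(-c2ccnc3[nH]ccc23)cc1` — 2700 nM
compound 4 `CN1CCN(S(=O)(=O)c2ccc(-c3ccnc4[nH]ccc34)cc2)CC1` — not yet measured

In an assay on isolated protein for inhibition of serine/threonine-protein kinase Nek1 (Homo sapiens), read by TR-FRET, with a stated time of 30 min (a lower number here means a stronger inhibitor, a higher number a weaker inhibitor), compound 1 gives 6600 nM. Compound 3 gives 2700 nM, the lowest of the two numbers available. For compound 2 the entry reads no result reported. Within the data shown here, the only step that has been measured is a 2.4-fold lower number from compound 1 to compound 3 (0.39 log units; beyond the scatter), an exchange of the group on the sulfonyl sulfur.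

Compound 4 changes the same place: 4-methylpiperazin-1-yl in place of (2-hydroxyethyl)(methyl)amino on a sulfonyl sulfur. Among the measured compounds shown here, the one step that bears on it is the one from compound 1 to compound 3, where a ring-bearing amino group gave way to the (2-hydroxyethyl)(methyl)amino group and the number fell modestly. Compound 4 brings a ring back and gives up the 1 hydrogen-bond donor, so a partial return toward the number of compound 1 seems the likelier outcome, though a step within the scatter cannot be ruled out. Compound 4 is therefore expected at 4000 nM, within 1800 nM to 9000 nM. This amounts to an expected step of a 1.5-fold higher number from compound 3 to compound 4 (0.17 log units; within the scatter).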

Compound 4, half-maximal inhibitory concentration: > 10000 nM
Compound 4 gave a limit, no number; the forecaster's own chance of this, stated with the estimate: 5%; middle value at least 2.5-fold (0.39 log units) from the limit.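

In this assay compound 4 gives only a limit, not a number: the limit of > 10000 nM in this assay, at which 1 of the 4 values shown sits. The step is an at least 3.7-fold higher number from compound 3 to compound 4 (0.56 log units; beyond the scatter), which shows that the exchange of (2-hydroxyethyl)(methyl)amino for 4-methylpiperazin-1-yl on the sulfonyl sulfur is not silent and that a second ring-bearing group also lies above the open-chain group of compound 3. The other step is an at least 1.5-fold higher number from compound 1 to compound 4 (0.18 log units; that floor lies within the scatter), and with that floor inside the scatter no order between these two ring-bearing groups can be read.

The exchange adds a ring and removes the hydroxyl hydrogen in one move, so the compounds shown do not separate the two changes. A 4-hydroxypiperidin-1-yl group or a plain dimethylamino group on the sulfonyl sulfur would bear on that question.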